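Swapping a ring for a chain on the thiocarbonyl carbon

The source may report more compounds than this note shows. Statements on the series, on what has been measured and on what is new or still open speak of the compounds shown alone.

Measured in a functional assay on A549 cells (Homo sapiens) for antiproliferative activity, read by MTT assay, with a stated time of 96 h; a lower number here means a stronger inhibitor, a higher number a weaker inhibitor:
- compound 1 `S=C(N/N=C1\CC2(CCCCC2)Oc2c1ccc1ccccc21)N1CCCCC1` gives 11400 nM
- compound 2 `S=C(N/N=C1\CC2(CCCCC2)Oc2c1ccc1ccccc21)N1CCOCC1` gives 10100 nM

Among the measured compounds shown here, these two values cannot be ranked, since the only measured step is a 1.1-fold lower number from compound 1 to compound 2 (0.05 log units; within the scatter). Compound 3 `NCCCCCCC(=S)N/N=C1\CC2(CCCCC2)Oc2c1ccc1ccccc21` has not been measured. It keeps the shared core but carries 6-aminohexyl in place of morpholin-4-yl on a thiocarbonyl carbon. That measured step changed the same place, but it exchanged one ring for another. For the measured compounds named here, no measured compound has an open chain there, so the data offer only a weak guide. With so little evidence, a small move towards a lower number in this assay is expected, though with wide uncertainty. The expected step is a 1.7-fold lower number from compound 2 to compound 3 (0.23 log units; within the scatter). The estimate for compound 3 is 6000 nM, with an expected range from 1500 nM to 20000 nM.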

Compound 3, half-maximal inhibitory concentration: 3240 nM
For compound 3 the middle estimate is 1.9-fold (0.27 log units) above the measured one, within the range that was stated.
By their numbers in this assay, from the lowest: compound 3; then compounds 2 and 1 (each within the scatter of the next).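

In this assay, putting 6-aminohexyl in place of a ring on the thiocarbonyl carbon gives a 3.1-fold lower number from compound 2 to compound 3 (0.49 log units; beyond the scatter), and a 3.5-fold lower number from compound 1 to compound 3 (0.55 log units; beyond the scatter); both steps are modest but lie beyond the scatter. The exchange of one ring for the other had shown no readable change, so this is the first sign that the number responds to what sits at this place, and that an open chain ending in an amine is tolerated there. The information available offers no independent evidence on why the open chain gives the lower number.

The compounds shown leave open whether the step comes from opening the ring or from the terminal amine. A plain hexyl chain without the amine, or a shorter or longer chain ending in an amine, would help separate these two possibilities.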